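The compounds below may be only part of what the source reports. "The series", "measured", "known", "first", "only" and "open" are said of these compounds alone.

Compound 3 `COc1ccc(-n2c(=O)n(Cc3cc4cc(Cl)ccc4n3CCCC#N)c3cnccc32)cc1OC` was tested in an ADME assay on HeLa cells (Homo sapiens) for cytotoxicity, read by ATP content, with a stated time of 3 days; a lower number here means that less compound is tolerated, a higher number that more compound is tolerated. For compound 3 the result is only a limit, > 50000 nM. Compound 1 `O=c1n(Cc2cc3cc(Cl)ccc3n2CCCC(F)(F)F)c2cnccc2n1C1CC1` also gives only a limit, > 50000 nM. Compound 2 `N#CCCCn1c(Cn2c(=O)n(-c3ccc(C(=O)NC4CC4)cc3)c3ccncc32)cc2cc(Cl)ccc21` likewise stops at a limit, > 50000 nM. Going by the values given here, the single measured step, a step that the two limits leave unreadable from compound 2 to compound 3, cannot be read, because of the limit of > 50000 nM in this assay, at which 3 of the 3 values shown sit. Compound 4 `Cn1ccc(-n2c(=O)n(Cc3cc4cc(Cl)ccc4n3CCCC#N)c3cnccc32)n1` differs from compound 3 in one place: 1-methyl-1H-pyrazol-3-yl in place of 3,4-dimethoxyphenyl on an aromatic nitrogen. Among the compounds with values here, no measured step shows how this exchange acts in this assay, since every value shown sits at the same limit. Compound 4 is therefore expected to remain at that limit, and the step that the limit leaves unreadable from compound 3 to compound 4 is expected to be none beyond the scatter. Compound 4 is estimated at 60000 nM, with a range from 25000 nM to 150000 nM.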

Compound 4, half-maximal cytotoxic concentration: > 50000 nM
Compound 4: no number, only a limit; the forecaster's own chance of this, stated with the estimate: 80%; the middle value is on the limit's open side.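

Neither step to compound 4, from compound 2 or from compound 3, can be read, and the reason is the same for both: the limit of > 50000 nM in this assay, at which 4 of the 4 values shown sit.

The compounds shown leave open whether 1-methyl-1H-pyrazol-3-yl, 3,4-dimethoxyphenyl and 4-(cyclopropylcarbamoyl)phenyl differ at all in how much compound is tolerated.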